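Benzyl thioether series: a chlorophenyl variant of compound 2

The source may report more compounds than this note shows. Statements on the series, on what has been measured and on what is new or still open speak of the compounds shown alone.

Compound 1 `CCCc1nnc(SCc2ccccc2)n1N1C(=O)c2ccccc2C1=O` carries a benzyl group on the sulfur. In a functional assay on A549 cells (Homo sapiens) for cytotoxicity, read by MTT assay, with a stated time of 48 h (on this read-out lower numbers stand for stronger inhibition and higher numbers for weaker inhibition), compound 1 gives only a limit of the assay, > 200000 nM. Compound 2 `CCCc1nnc(SCC(=O)c2ccc(C)cc2)n1N1C(=O)c2ccccc2C1=O` differs from it in a single place. In this assay compound 2 likewise gives only a limit, > 200000 nM. The step that the two limits leave unreadable from compound 1 to compound 2 therefore cannot be read, as both ends are limits; the shared position of both values is summed up in the limit of > 200000 nM in this assay, at which 2 of the 2 values shown sit. Compound 2 thus stands at the limit, with no number separating it from compound 1.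

Compound 3 `CCCc1nnc(SCc2ccccc2Cl)n1N1C(=O)c2ccccc2C1=O` is not yet measured in this assay. The change is 2-chlorophenyl in place of (4-methylphenyl)carbonyl on a saturated chain carbon bound to a sulfur. Within the data shown here, no measured step bears on this change beyond the unreadable one from compound 1 to compound 2, which shows only that both measured members sit at the limit. With two compounds at the limit and no readable step, the step that the limit leaves unreadable from compound 2 to compound 3 is expected to be none that can be seen, and compound 3 is expected to remain at or near the limit. The estimate for compound 3 in this assay is 300000 nM, within 80000 nM to 1500000 nM.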

Compound 3, half-maximal inhibitory concentration: > 200000 nM
Compound 3 gave a limit, no number (the forecaster's own chance of this, stated with the estimate: 80%); the middle value lies beyond the limit too.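

In this assay compound 3 gives > 200000 nM as a limit and no number. The steps to compound 3 from compound 1 and from compound 2 therefore cannot be read, and all three compounds share one position: the limit of > 200000 nM in this assay, at which 3 of the 3 values shown sit. The compounds shown leave open whether any group on the saturated chain carbon bound to a sulfur gives a readable value in this assay at all.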